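The source may report more compounds than this note shows. Statements on the series, on what has been measured and on what is new or still open speak of the compounds shown alone.

Of the compounds shown here, three have been tested in an ADME assay on cells (Peritoneal macrophage cell, Mus musculus) for cytotoxicity, read by fluorescence and resazurin assay, with a stated time of 3 days; a lower number here means that less compound is tolerated, a higher number that more compound is tolerated: compound 1 (`CC(C)Oc1cc(C(=O)Nc2cc(-c3ccccn3)n[nH]2)cc(C(=O)N2CCCC2)c1`), compound 2 (`O=C(Nc1cc(-c2ccccn2)n[nH]1)N1CCC(c2cccc(F)c2)CC1`) and compound 3 (`O=C(NCc1cccc(Cl)c1)Nc1cc(-c2ccccn2)n[nH]1`). Compound 1 gives > 40300 nM, which is a limit of the assay and not a number. Compound 2 gives > 45000 nM, which is also a limit. Compound 3 gives > 64000 nM, again a limit. Compound 2 therefore stands without a number of its own, as do the other two, and the three cannot be ranked against one another.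

Compound 4 (`O=C(Nc1cc(-c2ccccn2)n[nH]1)N1CCC(c2cccc(Cl)c2)CC1`) differs from compound 2 in a single place: chloro in place of fluoro on an aromatic carbon. The change turns 3-fluorophenyl into 3-chlorophenyl. Within the data shown here, no two tested compounds differ in only one place, so the data offer no measured step to size this change. The expectation in this assay is therefore no change beyond the usual scatter, in either direction. Its starting point is compound 2 at > 45000 nM, a limit. The estimated size of the change is a number no higher from compound 2 to compound 4 (the limit leaves the size open). For compound 4 the expected value is 45000 nM, with an estimated range from 20000 nM to 64000 nM, and the assay may well report only a limit again.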

Compound 4, half-maximal cytotoxic concentration: > 22000 nM
Compound 4: a limit, no number; the forecaster's own chance of this, stated with the estimate: 70%; the middle value is on the limit's open side.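

In this assay compound 4 gives > 22000 nM, a limit of the assay and not a number. Compound 2 also has only a limit, so no step can be read between compound 2 and compound 4. On these data alone, whether chloro in place of fluoro changes the tolerated concentration stays open, as does the actual value of each of the four compounds.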